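Flipping Two Ring Stereocentres on an Inactive Scaffold

This account rests on a few compounds, and the source may have more. Where it says the series, first, only, none or still open, it means among the compounds named here.

Two compounds have so far been examined in a functional assay on MCF7 cells (Homo sapiens) for cytotoxicity, read by MTT assay; a higher number here means a weaker inhibitor, a lower number a stronger inhibitor. Compound 1 `CC(=O)C1=C[C@@H]2[C@H](C(C)C)CC[C@@H](C)[C@]2(O)C1` reaches only a limit of the assay rather than a number: in this assay compound 1 gives > 10 ug/mL. Compound 2 `CC(=O)[C@H]1C[C@]2(O)[C@@H]([C@@H]1O)[C@H](C(C)C)CC[C@H]2C` is also reported only as a limit, and in this assay compound 2 gives > 10 ug/mL. Compound 2 therefore stands at the limit of > 10 ug/mL in this assay, at which 2 of the 2 values shown sit, with no measured number to mark it out. Compound 3 `CC(=O)[C@@H]1C[C@]2(O)[C@@H]([C@H]1O)[C@H](C(C)C)CC[C@H]2C` has not yet been tested. It keeps every atom and bond of compound 2, and the change is the two compounds have the same atoms and bonds and differ only in configuration as drawn: 2 of 6 stereo elements differ; a stereocentre at a saturated ring carbon is drawn S in compound 2 and R in compound 3; a stereocentre at a saturated ring carbon is drawn S in compound 2 and R in compound 3. Going by the values given here, because compound 2 sits at the limit of > 10 ug/mL in this assay, at which 2 of the 2 values shown sit, no step between measured compounds can be computed to guide the expectation. The step expected in this assay is a step that the limit leaves unreadable from compound 2 to compound 3, nothing beyond the scatter. Compound 3 is accordingly estimated to give 15 ug/mL, within a range from 8 ug/mL to 40 ug/mL.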

Compound 3, half-maximal inhibitory concentration: > 10 ug/mL
Compound 3: no number, only a limit; the forecaster's own chance of this, stated with the estimate: 80%; the middle value does not contradict the limit.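

In this assay, going by these compounds alone, compound 2 and compound 3 are both reported only as limits, so no step between them can be read. The compounds shown leave open whether the configuration at these two saturated ring carbons affects cytotoxicity at all, as none gives an actual number.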